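This account rests on a few compounds, and the source may have more. Where it says the series, first, only, none or still open, it means among the compounds named here.

Compound 1 `COCCNc1nc(C)cc2c1c(N)nn2C` and compound 2 `COCCNc1nc(-c2ccccc2)cc2c1c(N)nn2C` share one core and differ at a single carbon. In an assay on isolated protein for inhibition of ribosomal protein S6 kinase alpha-5 (Homo sapiens), read by mobility shift assay, tested at 30 uM (a higher number here means more inhibition at the concentration tested (going by the name of the read-out), a lower number less inhibition), compound 1 gives 0%, and in this assay compound 2 gives 0%. The step of no change at the digits printed from compound 1 to compound 2 (within the scatter), phenyl in place of methyl on an aromatic carbon, leaves the read-out flat. Compound 2 therefore stands level with compound 1 at the digits shown, with no measured neighbour showing any inhibition. Compound 3 `Cn1nc(N)c2cnc(-c3ccccc3)cc21` has not yet been tested in this assay. It differs from compound 2 by hydrogen in place of (2-methoxyethyl)amino on an aromatic carbon. Going by the values given here, no measured step touches this group; the only step known, no change at the digits printed from compound 1 to compound 2 (within the scatter), concerns another carbon and shows no change, so it bears on the question only loosely. With the inhibition of both measured compounds level in this assay, the expected step of a number 2 percentage points higher from compound 2 to compound 3 (within the scatter) is none beyond the scatter. Compound 3 is accordingly estimated at 2%, in a range from 0% to 12%.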

Compound 3, a percentage reported as inhibition, at one concentration (the size of the read-out at that concentration, not a potency): 4%
The estimate for compound 3 lay 2 percentage points below the measured number; the measured number falls inside the stated range.
By their numbers in this assay, from the lowest: compounds 1, 2 and 3 (each within the scatter of the next).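

In this assay, replacing (2-methoxyethyl)amino with hydrogen on this aromatic carbon, next to the ring nitrogen, gives a number 4 percentage points higher from compound 2 to compound 3 (within the scatter). Going by these compounds alone, this is the first look at this position, and it shows that the whole chain can go without the read-out moving beyond the scatter, just as the phenyl for methyl exchange on the other carbon left it flat. No measurement shown bears on why the read-out stays flat at either position.

Since all three compounds sit within the scatter of one another, the compounds shown leave open whether any group on this carbon, such as a piperazine or a carboxylic acid, would give inhibition beyond the scatter. They also leave open whether hydrogen here would read the same with methyl instead of phenyl on the other carbon.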